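Bromo in place of hydroxy: compound 2 to compound 4

A few compounds are considered here, and "the series" means these few. Any claim that something is new, unique, unknown or untested is made for them only; others in the source may bear on it.

Compound 1 `CC(C)=C1C(=O)N(c2ccc(Cl)cc2)N(c2ccc(Cl)cc2)C1=O`: 45600 nM
Compound 2 `O=C1C(=Cc2ccc(O)cc2)C(=O)N(c2ccc(Cl)cc2)N1c1ccc(Cl)cc1`: 20600 nM
Compound 3 `O=C1C(=Cc2ccc(F)cc2)C(=O)N(c2ccc(Cl)cc2)N1c1ccc(Cl)cc1`: 23300 nM
Compound 4 `O=C1C(=Cc2ccc(Br)cc2)C(=O)N(c2ccc(Cl)cc2)N1c1ccc(Cl)cc1`: not yet measured

All values come from a functional assay on SMMC-7721 cells (Homo sapiens) for cytotoxicity, read by MTT assay, with a stated time of 72 h (on this read-out higher numbers stand for weaker inhibition and lower numbers for stronger inhibition), and are compared here on that scale. Compound 2 stands at the low end of the three numbers. It is level with compound 3 within the scatter, and compound 1 gives a higher number than compound 2, beyond the scatter.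

Compound 4 has bromo in place of hydroxy on an aromatic carbon and is otherwise the same as compound 2. For the measured compounds named here, one measured step bears on this change: a 1.1-fold higher number from compound 2 to compound 3 (0.05 log units; within the scatter) puts fluoro at the same place and stays within the scatter. Going by the values given here, no measured compound carries bromo, so this single step is thin support. No change beyond the scatter is expected, and the expected step is a 1.0-fold higher number from compound 2 to compound 4 (0.01 log units; within the scatter) on this reasoning. Compound 4 is estimated at 21000 nM with an expected range of 11000 nM to 40000 nM as the working figure.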

Compound 4, half-maximal inhibitory concentration: 16600 nM
Compound 4: the middle estimate sits 1.3-fold (0.10 log units) above what was measured, and the stated range covers the measured number.
By their numbers in this assay, from the lowest: compounds 4, 2, 3 and 1 (each within the scatter of the next, the first and the last beyond it).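

In this assay the exchange of hydroxy for bromo gives a 1.2-fold lower number from compound 2 to compound 4 (0.09 log units; within the scatter) and the exchange of fluoro for bromo gives a 1.4-fold lower number from compound 3 to compound 4 (0.15 log units; within the scatter) and neither step leaves the scatter. Compound 2, compound 3 and compound 4 therefore stand level, and replacing the hydroxy, with its hydrogen-bond donor and acceptor, by either halogen on this aromatic carbon shifts nothing that can be read here. Nothing measured accounts for this flat result.

Open, on these data alone, is whether any group at this place moves the number beyond the scatter, for instance an amine, a carboxylic acid or a longer chain such as butoxy. Also open, as far as these compounds go, is whether the level standing of these three compounds holds in other cell lines.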